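Cytotoxicity Limits Across Chain-Terminus Variants of a Nucleoside

The source may report more compounds than this note shows. Statements on the series, on what has been measured and on what is new or still open speak of the compounds shown alone.

Compound 3 `Cc1cn(C2CC(N=[N+]=[N-])C(COC(=O)OCCCC(=O)O)O2)c(=O)[nH]c1=O` is the reference point here. In a functional assay on MT4 cells (Homo sapiens) for cytotoxicity (on this read-out higher numbers stand for lower toxicity in this test and lower numbers for higher toxicity in this test), compound 3 gives > 50000 nM, which is a limit of the assay rather than a number. Its two neighbours share the same core. Compound 1 `Cc1cn(C2CC(N=[N+]=[N-])C(COC(=O)OCCCCCCCCO)O2)c(=O)[nH]c1=O` carries a 5-hydroxypentyl group at the chain end, and in this assay compound 1 gives > 50000 nM, again a limit. Compound 2 `Cc1cn(C2CC(N=[N+]=[N-])C(COC(=O)OCCCO)O2)c(=O)[nH]c1=O` carries a hydroxy group at that position, and in this assay compound 2 gives > 50000 nM, also a limit. The steps a step that the two limits leave unreadable from compound 1 to compound 2, a step that the two limits leave unreadable from compound 1 to compound 3 and a step that the two limits leave unreadable from compound 2 to compound 3 therefore cannot be sized; what is known is the limit of > 50000 nM in this assay, at which 3 of the 3 values shown sit.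

Compound 4 `Cc1cn(C2CC(N=[N+]=[N-])C(COC(=O)OCCCCCO)O2)c(=O)[nH]c1=O` differs from compound 3 by 2-hydroxyethyl in place of carboxy on a saturated chain carbon, three bonds along the chain from an oxygen next to a carbonyl group. The closest measured step, from compound 2 to compound 3, is the unreadable one above, so no direction can be read from it. Since every measured value sits at the limit due to the limit of > 50000 nM in this assay, at which 3 of the 3 values shown sit, compound 4 is expected to sit there as well, with a step that the limit leaves unreadable from compound 3 to compound 4 expected to be no step beyond the scatter. Compound 4 is estimated at 100000 nM, between 50000 nM and 300000 nM, most likely reported only as a limit.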

Compound 4, half-maximal cytotoxic concentration: > 50000 nM
Compound 4 gave a limit, no number (the forecaster's own chance of this, stated with the estimate: 90%); the middle value does not contradict the limit.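

Compound 4, like compound 1, compound 2 and compound 3, gives only a limit in this assay, so none of its steps to those compounds can be read: the limit of > 50000 nM in this assay, at which 4 of the 4 values shown sit.

The compounds shown leave open whether any chain-end group shifts this read-out to a measurable value.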